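The compounds below may be only part of what the source reports. "The series", "measured", "known", "first", "only" and "open" are said of these compounds alone.

Working notes on the series. Three compounds have been run in an assay on isolated protein for inhibition of A disintegrin and metalloproteinase with thrombospondin motifs 5 (Homo sapiens); on this read-out lower numbers stand for stronger inhibition and higher numbers for weaker inhibition. Compound 1 `O=C(O)[C@]1(NS(=O)(=O)c2ccc(-c3ccc(Cl)cc3)s2)C[C@@H]1c1ccccc1` gives 60 nM. Compound 2 `C[C@@H]1[C@H](c2ccccc2)[C@]1(NS(=O)(=O)c1ccc(-n2cc(Cl)cn2)s1)C(=O)O` gives 7.4 nM. Compound 3 `C[C@]1(c2ccccc2)C[C@@]1(NS(=O)(=O)c1ccc(-c2ccc(Cl)cc2)s1)C(=O)O` gives 10 nM. Compound 2 has the lowest number of the three; the gap to compound 3 lies within the scatter of repeated measurements, so no order between those two can be claimed, while the gap to compound 1 lies beyond the scatter. All three share the carboxy group and the sulfonamide on the three-membered ring, and differ in the substituents around that ring and at the far end of the sulfonyl-bearing part.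

The next compound follows on from compound 2. Compound 4 `C[C@@H]1[C@H](C)[C@]1(NS(=O)(=O)c1ccc(-n2cc(Cl)cn2)s1)C(=O)O` differs from compound 2 in one place: methyl in place of phenyl on a saturated ring carbon. Within the data shown here, no measured pair in the set separates this change from others, so nothing in the present numbers tells its size directly. The phenyl leaves and a methyl enters on the saturated ring carbon. For compound 4 the expected outcome is a weaker inhibition than compound 2, with a step from compound 2 to compound 4 of a 20-fold higher number from compound 2 to compound 4 (1.31 log units; beyond the scatter) that is estimated to lie beyond the scatter. In this assay compound 4 is estimated at 150 nM, with a range of 40 nM to 600 nM.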

Compound 4, half-maximal inhibitory concentration: 800 nM
The estimate for compound 4 lay 5.3-fold (0.73 log units) below the measured number; measured number outside the range, above it.
By their numbers in this assay, from the lowest: compounds 2 and 3 (each within the scatter of the next); then compound 1; then compound 4.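

In this assay, among these compounds, methyl in place of phenyl on a saturated ring carbon gives a 110-fold higher number from compound 2 to compound 4 (2.03 log units; beyond the scatter), and this is the first comparison that changes one place only. The step is large and lies beyond the scatter, so this ring carbon is not indifferent to its substituent: with the rest of the structure held constant, including the neighbouring methyl group and the carboxy group, the exchange of a six-membered aromatic ring for a single carbon is enough to weaken inhibition markedly. No measurement at hand bears on what lies behind the size of this step.

From the compounds shown here alone, it remains open whether the aromatic ring itself matters or whether the number of carbons at this position is enough: a cyclohexyl group or a longer chain such as n-butyl on the same ring carbon would separate those two readings, and a pyridyl group would show whether the all-carbon ring is needed. Also open, going by these compounds, is whether the same exchange carries the same size when the far end of the sulfonyl-bearing part is a 4-chlorophenyl group.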